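Nitro for Methyl on the Ether-Linked Ring of Compound 3

The source may hold more compounds than are shown below. What is called first, only, known or untested is meant among the compounds shown, and "the series" means these compounds.

Compound 3 `Cc1cccc(COc2ccc(C3=NN(CCC#N)C(=O)CO3)cc2)c1` gives 40000 nM in an assay for inhibition of Amine oxidase [flavin-containing] A (Rattus norvegicus) (on this read-out lower numbers stand for stronger inhibition and higher numbers for weaker inhibition), the highest of the three numbers recorded. Compound 1 `Cc1cccc(COc2ccc(-c3nn(CCC#N)c(=S)o3)cc2)c1` gives 14000 nM, and compound 2 `Cc1ccc(COc2ccc(-c3nn(CCC#N)c(=S)o3)cc2)cc1` gives 10000 nM. The step of a 1.4-fold lower number from compound 1 to compound 2 (0.15 log units; within the scatter) replaces 3-methylphenyl with 4-methylphenyl and lies within the scatter. Compound 4 `N#CCCN1N=C(c2ccc(OCc3ccc([N+](=O)[O-])cc3)cc2)OCC1=O` differs from compound 3 by 4-nitrophenyl in place of 3-methylphenyl on a saturated chain carbon bound to an oxygen on an aromatic ring. Within the data shown here, no measured step exchanges a methyl group for a nitro group, and compound 3 carries a different core from compounds 1 and 2, so the single step that changes a group on this ring bears on the present change only loosely. Because that step a 1.4-fold lower number from compound 1 to compound 2 (0.15 log units; within the scatter) stayed within the scatter, the author expects for compound 4 no step beyond the scatter in this assay, in either direction, while allowing wide uncertainty for the untested nitro group. Compound 4 is expected to give 30000 nM, between 8000 nM and 110000 nM. The expected step of a 1.3-fold lower number from compound 3 to compound 4 (0.12 log units; within the scatter) is therefore small.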

Compound 4, half-maximal inhibitory concentration: 2000 nM
The estimate for compound 4 lay 15-fold (1.18 log units) above the measured number, and the stated range ends above it.
By their numbers in this assay, from the lowest: compound 4; then compounds 2 and 1 (each within the scatter of the next); then compound 3.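

In this assay the exchange of 3-methylphenyl for 4-nitrophenyl on a saturated chain carbon bound to an oxygen on an aromatic ring gives a 20-fold lower number from compound 3 to compound 4 (1.30 log units; beyond the scatter) and so shows that this position can respond strongly to the group it carries. The earlier step at this position, a 1.4-fold lower number from compound 1 to compound 2 (0.15 log units; within the scatter), moved only the methyl group's place on the ring and gave no such sign. Nothing available accounts for the size of the new step.

The step changes both the group and its place on the ring, so the compounds shown do not separate the nitro group from the move to the 4-position, nor show whether the gain carries over to the core of compound 1. Going by these compounds, how an amine or a carboxylic acid would read at this position also remains open.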